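Pyridine-aryl acrylamides and acids: growth inhibition notes

The compounds below may be only part of what the source reports. "The series", "measured", "known", "first", "only" and "open" are said of these compounds alone.

Measured compounds:
compound 1 `O=C(O)/C=C/c1ccncc1-c1ccc2cc[nH]c2c1`; compound 2 `CNC(=O)CCc1ccncc1-c1ccc2ccccc2c1`; compound 3 `O=C(O)/C=C/c1ccncc1-c1ccc2[nH]ccc2c1`

In a functional assay on MCF7 cells (Homo sapiens) for inhibition, read by sulforhodamine B assay, with a stated time of 72 h (on this read-out higher numbers stand for weaker inhibition of growth and lower numbers for stronger inhibition of growth), compound 1 gives only a limit, > 10000 nM. For compound 2 the result is likewise a limit, > 10000 nM. Compound 3 also reaches only a limit, > 10000 nM. Thus compound 2 stands at the limit of > 10000 nM in this assay, at which 3 of the 3 values shown sit; no step between measured compounds can be sized from these three.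

Compound 4 `CN(C)C(=O)/C=C/c1ccncc1-c1ccc2ccccc2c1` is not yet measured. It differs from compound 2 as follows: 2-(dimethylcarbamoyl)ethenyl in place of 2-(methylcarbamoyl)ethyl on an aromatic carbon. Since compound 2 shows only a limit, no clear direction can be drawn for this step; a result near the same limit, or any change within the scatter, is the expectation.

Compound 4 is expected to give about 15000 nM, between 5000 nM and 50000 nM, a step that the limit leaves unreadable from compound 2 to compound 4 that is expected to be small.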

Compound 4, concentration for 50% growth inhibition: 8190 nM
For compound 4 the middle estimate is 1.8-fold (0.26 log units) above the measured one; measured number inside the range.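

In this assay, among the compounds shown here, compound 4 is the first compound to give a number rather than a limit, so this position on the shared core can carry a measurable growth-inhibiting compound. The change reads as an at least 1.2-fold lower number from compound 2 to compound 4 (0.08 log units; that floor lies within the scatter). That step has only a floor, and its true size cannot be read: the limit of > 10000 nM in this assay, at which 3 of the 4 values shown sit.

The step combines the chain double bond with the loss of the amide hydrogen, and the compounds shown do not separate the two. From the compounds shown here alone, whether an amine or a longer chain at this position would give a lower number also remains open.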